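The source may report more compounds than this note shows. Statements on the series, on what has been measured and on what is new or still open speak of the compounds shown alone.

Compound 1 `CCCOc1ccc(C(=O)Nc2cccc(C)n2)cc1` gives 11100 nM in an in vitro assay on HEK-tsA201 cells for antagonist activity at Neuronal acetylcholine receptor; alpha3/beta4 (Homo sapiens), read by fluorescence and calcium flux; a lower number here means a stronger inhibitor, a higher number a weaker inhibitor. Compound 2 `C=CCOc1ccc(C(=O)Nc2cccc(Cl)n2)cc1` reaches only the limit of > 100000 nM in this assay. Compound 3 `CCCOc1ccc(C(=O)Nc2cccc(Br)n2)cc1` likewise reaches only the limit of > 100000 nM in this assay.

Compound 3 thus stands at the limit of the assay rather than at a number, and the limit of > 100000 nM in this assay, at which 2 of the 3 values shown sit, is where two of the three values gather. Within the data shown here, the only measured change at a single place runs from methyl to bromo: an at least 9.0-fold higher number from compound 1 to compound 3 (0.95 log units; beyond the scatter). Compound 4 `CCCOc1ccc(C(=O)Nc2cccc(Cl)n2)cc1` differs from compound 3 by chloro in place of bromo on an aromatic carbon. Among the measured compounds shown here, no measured step sets chloro against bromo directly. Compound 2 also carries chloro and sits at a limit, though it differs from compound 3 in a second place as well, so it gives a hint rather than a measured step.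

Given that compound 3 itself sits at a limit and the nearest chloro-bearing compound 2 does too, compound 4 is expected to remain at or near that limit, and the step that the limit leaves unreadable from compound 3 to compound 4 is expected to be none beyond the scatter. Compound 4 is therefore estimated at 150000 nM, with a range from 40000 nM to 600000 nM.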

Compound 4, half-maximal inhibitory concentration: > 100000 nM
Compound 4: a limit, no number; the forecaster's own chance of this, stated with the estimate: 75%; the middle value is on the limit's open side.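

Among these compounds, compound 4 adds a comparison the earlier compounds lacked, a change from methyl to chloro on the aromatic carbon next to the ring nitrogen, with the rest of the molecule kept the same: an at least 9.0-fold higher number from compound 1 to compound 4 (0.95 log units; beyond the scatter). Bromo and chloro have now each replaced the methyl of compound 1 in this assay, and both replacements give a higher number by a margin beyond the scatter, leaving compound 1 as the only compound shown with a number rather than a limit: the limit of > 100000 nM in this assay, at which 3 of the 4 values shown sit. The steps from compound 3 to compound 4 and from compound 2 to compound 4 cannot be read, as both ends of each step are limits, so no order between chloro and bromo or between the ethyl and vinyl versions can be drawn.

From the compounds shown here alone, whether an ethyl group, a methoxy group or an amine at this place would keep a readable number remains open. Also open, going by these compounds, is whether any group here could give a lower number than compound 1, which gives 11100 nM.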